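Microsomal half-life notes: amino variation on the diethyl core

The compounds below may be only part of what the source reports. "The series", "measured", "known", "first", "only" and "open" are said of these compounds alone.

Measured so far in an in vitro ADME assay on microsomes (Rattus norvegicus) for metabolic stability; on this read-out lower numbers stand for a shorter-lived compound and higher numbers for a longer-lived compound:
compound 1, `CCc1nc(-c2ccc(Cl)cc2Cl)c(CC)nc1NC(CC)CC`: 0.07 h
compound 2, `CCc1nc(-c2ccc(Cl)cc2Cl)c(CC)nc1CC(CC)CC`: 0.0417 h
compound 3, `CCc1nc(N(CC2CC2)CC2CC2)c(CC)nc1-c1ccc(Cl)cc1Cl`: reported only as a limit, < 0.0167 h

Compound 3 stands at the low end of the numbers shown, and its entry is a limit of this assay (the limit of < 0.0167 h in this assay, at which 1 of the 3 values shown sits), so only the sign is known. The step of an at least 4.1-fold lower number from compound 1 to compound 3 (0.62 log units; beyond the scatter) lies beyond the scatter, as does the step of an at least 2.4-fold lower number from compound 2 to compound 3 (0.39 log units; beyond the scatter). The step of a 1.7-fold lower number from compound 1 to compound 2 (0.22 log units; within the scatter) is within the scatter.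

Compound 4, `CCc1nc(-c2ccc(Cl)cc2Cl)c(CC)nc1NC(COC)COC`, is not yet measured. (2-methoxy-1-(methoxymethyl)ethyl)amino in place of bis(cyclopropylmethyl)amino on an aromatic carbon The step that bears on this change is an at least 4.1-fold lower number from compound 1 to compound 3 (0.62 log units; beyond the scatter), since it runs the opposite way: a secondary amino with a branched chain gives way to bis(cyclopropylmethyl)amino there, whereas here a secondary amino returns, as (2-methoxy-1-(methoxymethyl)ethyl)amino rather than the (pentan-3-yl)amino of compound 1. That measured step was at least modest and downward, so an upward step in this assay is expected from compound 3 to compound 4, with its size uncertain because the starting point is a limit.

Compound 4 is expected at 0.06 h, with range 0.02 h to 0.2 h. The expected step is an at least 3.5-fold higher number from compound 3 to compound 4 (0.55 log units; beyond the scatter).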

Compound 4, half-life: 0.0417 h
Estimate against measurement, compound 4: 1.4-fold (0.16 log units) above, within the range that was stated.
By their numbers in this assay, from the lowest: compounds 2, 4 and 1 (each within the scatter of the next). At a limit, below all of these: compound 3.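

In this assay, the new secondary amino group takes the position out of the limit seen with bis(cyclopropylmethyl)amino, with an at least 2.4-fold higher number from compound 3 to compound 4 (0.39 log units; beyond the scatter), and this step has only a lower bound, as the entry for compound 3 is a limit: the limit of < 0.0167 h in this assay, at which 1 of the 4 values shown sits.

The more telling comparisons are the other two: a 1.7-fold lower number from compound 1 to compound 4 (0.22 log units; within the scatter), so placing 2-methoxy-1-(methoxymethyl)ethyl in place of pentan-3-yl on the same nitrogen does not separate the two compounds, and no change at the digits printed from compound 2 to compound 4 (within the scatter), so the same holds against the 2-ethylbutyl group, which has no amino nitrogen. Among the four compounds, only compound 3 stands apart at this position, and the ether oxygens of compound 4 bring no gain in half-life over compound 1 or compound 2 in this assay.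

Going by these compounds, how far compound 3 lies under its limit stays open, so the full size of its steps is unknown. Also open, on these data alone, is whether a tertiary amino group without cyclopropyl rings, such as diethylamino or morpholine, would fall with compound 3 or with the other three.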